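Changing the Aryl Group on the Cyclopropyl Ring

The compounds below may be only part of what the source reports. "The series", "measured", "known", "first", "only" and "open" are said of these compounds alone.

Compound 1 `CC[C@H](C)[C@H](N)CN(C(=O)[C@@H]1C[C@H]1c1ccccc1)c1ccc(-c2ccccc2)cc1`: 230 nM; 800 nM (2 entries)
Compound 2 `CC[C@H](C)[C@H](N)CN(C(=O)[C@@H]1C[C@H]1c1ccc(Cl)cc1)c1ccc(-c2ccccc2)cc1`: 4300 nM
Compound 3 `CC[C@H](C)[C@H](N)CN(C(=O)[C@@H]1C[C@H]1c1ccc(OC)cc1)c1ccc(-c2ccccc2)cc1`: > 25000 nM

In a functional assay for agonist activity at G protein-coupled receptor 88 (Homo sapiens), read by HTRF and cAMP accumulation (a higher number here means that more compound is needed for the effect, a lower number that less compound is needed), compound 1 gives 230 nM; 800 nM (2 entries), and compound 2 gives 4300 nM. Compound 3 reaches only the limit of this assay, > 25000 nM, and no number is available for it. Of the three measured compounds, compound 3 thus stands at the weak end, beyond the limit, as the further entry without a number confirms (the limit of > 25000 nM in this assay, at which 1 of the 3 values shown sits).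

Compound 4 `CC[C@H](C)[C@H](N)CN(C(=O)[C@@H]1C[C@H]1c1ccccc1F)c1ccc(-c2ccccc2)cc1` differs from compound 3 by 2-fluorophenyl in place of 4-methoxyphenyl on a saturated ring carbon. For the measured compounds named here, the one measured step that bears on this position is an at least 5.8-fold higher number from compound 2 to compound 3 (0.76 log units; beyond the scatter), which shows that a change of the group on this phenyl ring can move the number considerably. Since compound 4 carries a small substituent on a ring much like that of compound 1, the expectation is a return toward the range of compound 1, whose repeated entries (the several entries of compound 1 in this assay, 230 nM; 800 nM (2 entries)) define the uncertainty. Compound 4 is therefore expected to give 1500 nM, within 300 nM to 8000 nM. The estimated step, an at least 16-fold lower number from compound 3 to compound 4 (1.22 log units; beyond the scatter), is expected to be large and toward a lower number.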

Compound 4, half-maximal effective concentration: 650 nM
The estimate for compound 4 lay 2.3-fold (0.36 log units) above the measured number, within the range that was stated.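

For compound 3 the entry > 25000 nM is only a limit of this assay, not a number. The 2-fluorophenyl group nevertheless gives a clear return from that limit, an at least 38-fold lower number from compound 3 to compound 4 (1.58 log units; beyond the scatter), and also stands apart from the 4-chlorophenyl group, a 6.6-fold lower number from compound 2 to compound 4 (0.82 log units; beyond the scatter), so a substituted phenyl at this place on the three-membered ring is compatible with a measurable value. Compound 4, at 650 nM, lies inside the span of the entries of compound 1, 230 nM; 800 nM (2 entries), whereas the two 4-substituted phenyl compounds both print higher values.

Because 2-fluorophenyl differs from 4-chlorophenyl in both the atom and its place on the ring, these compounds do not separate the two changes. Also open, going by these compounds, is how 4-fluorophenyl, 2-chlorophenyl or 2-methoxyphenyl would behave here.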